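Removing the methyl group from compound 2

This account rests on a few compounds, and the source may have more. Where it says the series, first, only, none or still open, it means among the compounds named here.

Two members of the series have numbers in an assay on cells for inhibition of cytochrome P450 11B2, mitochondrial (Homo sapiens), read by HTRF; a lower number here means a stronger inhibitor, a higher number a weaker inhibitor. Compound 1 `O=C(Nc1cccnc1)c1ccc(Cl)cc1F` gives 297 nM, and compound 2 `Cc1cc(Cl)ccc1C(=O)Nc1cccnc1` gives 277 nM. Compound 2 has the lowest of the two numbers, with compound 1 nearest; the step of a 1.1-fold lower number from compound 1 to compound 2 (0.03 log units; within the scatter) is within the scatter, so the two values cannot be ordered.

The next compound, compound 3 `O=C(Nc1cccnc1)c1ccc(Cl)cc1`, differs from compound 2 at a single position: hydrogen in place of methyl on an aromatic carbon. Within the data shown here, the only measured step that touches this position is a 1.1-fold lower number from compound 1 to compound 2 (0.03 log units; within the scatter), and it stayed within the scatter. Among the measured compounds shown here, no measured pair removes a substituent from this carbon altogether, so the size of the step to compound 3 in this assay has no direct precedent; the one comparison at hand shows a change between fluoro and methyl there without a shift beyond the scatter. The expected step is therefore a 1.3-fold higher number from compound 2 to compound 3 (0.10 log units; within the scatter), meaning no change beyond the scatter, with wider uncertainty than for the measured pair. On that basis compound 3 is estimated at 350 nM, within a range from 150 nM to 900 nM.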

Compound 3, half-maximal inhibitory concentration: 420 nM
Beside the measured number, compound 3's estimate is 1.2-fold (0.08 log units) below it; low and high end bracket the measured number.
By their numbers in this assay, from the lowest: compounds 2, 1 and 3 (each within the scatter of the next).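

In this assay this aromatic carbon can now be read with no substituent on it, which neither earlier compound allowed. Removing the methyl group gives a 1.5-fold higher number from compound 2 to compound 3 (0.18 log units; within the scatter) and replacing the fluoro group with hydrogen gives a 1.4-fold higher number from compound 1 to compound 3 (0.15 log units; within the scatter) so neither step goes beyond the scatter. Hydrogen, fluoro and methyl at this place, ortho to a group of 9 heavy atoms and meta to a chloro group, therefore cannot be ordered, and across these three compounds a substituent on this carbon is not shown to matter for the number in this assay. No supporting measurement is available to help interpret these steps.

The compounds shown leave open whether a larger or different group on this carbon, such as a methoxy group, an amine, a carboxylic acid or a longer chain, would move the number beyond the scatter. Going by these compounds, the chloro group and the rest of the shared core stay the same in all three compounds, so it also remains open whether the same flat reading at this carbon would hold with another group in place of chloro.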